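Acetamido for fluoro: expectation for compound 4

A few compounds are considered here, and "the series" means these few. Any claim that something is new, unique, unknown or untested is made for them only; others in the source may bear on it.

Compound 1 `N#CC1=C(N)Oc2c(c3nc4ccccc4nc3c3ccccc23)C12C(=O)N(Cc1cnnn1-c1ccccc1Cl)c1ccccc12` in a functional assay on HCT-116 cells (Homo sapiens) for antiproliferative activity, read by MTT assay, with a stated time of 48 h; on this read-out lower numbers stand for stronger inhibition and higher numbers for weaker inhibition: > 50000 nM, a limit.
Compound 2 `CCOc1ccc(-n2nncc2CN2C(=O)C3(C(C#N)=C(N)Oc4c3c3nc5ccccc5nc3c3ccccc43)c3ccccc32)cc1` in this assay: > 50000 nM, a limit.
Compound 3 `N#CC1=C(N)Oc2c(N)cc3nc4ccccc4nc3c2C12C(=O)N(Cc1cnnn1-c1ccc(F)cc1)c1ccccc12` in this assay: > 50000 nM, a limit.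

For the measured compounds named here, every value measured so far sits at the same limit, (the limit of > 50000 nM in this assay, at which 3 of the 3 values shown sit), and none is a number. Compound 3 therefore stands at a limit only, and the two other compounds give nothing to rank it against. Going by the values given here, the one step between measured compounds, a step that the two limits leave unreadable from compound 1 to compound 2, is unreadable, both of its ends being limits.

Compound 4 `CC(=O)Nc1ccc(-n2nncc2CN2C(=O)C3(C(C#N)=C(N)Oc4c(N)cc5nc6ccccc6nc5c43)c3ccccc32)cc1` differs from compound 3 by acetamido in place of fluoro on an aromatic carbon. Among the compounds with values here, no measured step bears on this change: the single step in hand has no readable size, and the rest of the set shows limits alone. Nothing here suggests that the acetamido group would bring compound 4 into the readable range of this assay. Compound 4 is estimated at 60000 nM, with a range from 20000 nM to 200000 nM. The expected step is a step that the limit leaves unreadable from compound 3 to compound 4, and the most likely outcome is that the assay again reports only a limit.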

Compound 4, half-maximal inhibitory concentration: > 50000 nM
Compound 4: no number, only a limit; the forecaster's own chance of this, stated with the estimate: 85%; the middle value is on the limit's open side.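

For the compounds shown here, compound 3 and compound 4 both stand at a limit in this assay, so no step between them can be read. The compounds shown leave open whether any change to this series gives a measurable number in this assay: the limit of > 50000 nM in this assay, at which 4 of the 4 values shown sit.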